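The compounds below may be only part of what the source reports. "The series", "measured", "known", "first", "only" and "open" are said of these compounds alone.

Measured so far:
compound 1 `CC(C)C(=O)N1CC2CC(C1)N2` – 19000 nM
compound 2 `O=C(CC1C=CCC1)N1CC2CC(C1)N2` – 14000 nM

In an assay on SH-EP1 cells for agonist activity at Neuronal acetylcholine receptor; alpha4/beta2 (Homo sapiens), read by FLIPR and calcium flux (on this read-out higher numbers stand for an effect only at larger amounts of compound and lower numbers for an effect already at smaller amounts), compound 1 gives 19000 nM. Compound 2 gives 14000 nM, and the two numbers lie within the usual scatter of one another, so compound 1 stands apart from nothing in this small set. Compound 3 `O=C([C@@H]1C[C@@H]1F)N1CC2CC(C1)N2` differs from compound 1 by 2-fluorocyclopropyl in place of isopropyl on a carbonyl carbon. Within the data shown here, no measured pair shows what such a change does, and the two measured compounds sit close together, so nothing points to a move beyond the scatter. Compound 3 is expected at 13000 nM, with a range from 4000 nM to 40000 nM. The expected step of a 1.5-fold lower number from compound 1 to compound 3 (0.16 log units; within the scatter) thus stays within the scatter.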

Compound 3, half-maximal effective concentration: 120 nM
Compound 3: middle estimate off by 110-fold (2.03 log units), on the high side; the measured number lies below the stated range.
By their numbers in this assay, from the lowest: compound 3; then compounds 2 and 1 (each within the scatter of the next).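

In this assay, 2-fluorocyclopropyl in place of isopropyl on a carbonyl carbon gives a 160-fold lower number from compound 1 to compound 3 (2.20 log units; beyond the scatter). This position can therefore shift the read-out strongly, which the values of compound 1 and compound 2 alone did not show. Nothing available bears on why the step is this large.

On these data alone, whether the step follows the three-membered ring, the fluorine or the particular stereocentres stays open. Plain cyclopropyl and the other stereoisomers of 2-fluorocyclopropyl are not among the compounds shown, and they would separate these contributions.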